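The source may hold more compounds than are shown below. What is called first, only, known or untested is meant among the compounds shown, and "the series" means these compounds.

Compound 1 `CCCCc1ccc(Nc2nc3nonc3nc2O)cc1` and compound 2 `CCCCc1ccc(Nc2nc3nonc3nc2O)c(F)c1` share one core, and compound 3 `Oc1nc2nonc2nc1Nc1ccc(C(F)(F)F)cc1` carries another. In an assay on mitochondria from L6 cells (Rattus norvegicus) for activation, with a stated time of 90 min (on this read-out lower numbers stand for an effect already at smaller amounts and higher numbers for an effect only at larger amounts of compound), compound 1 gives 2100 nM, compound 2 gives 1100 nM and compound 3 gives 10400 nM. The change from compound 1 to compound 2 is fluoro in place of hydrogen on an aromatic carbon and brought a 1.9-fold lower number from compound 1 to compound 2 (0.28 log units; within the scatter). The two cores differ by trifluoromethyl in place of butyl on an aromatic carbon, a change that brought a 5.0-fold higher number from compound 1 to compound 3 (0.69 log units; beyond the scatter).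

Compound 4 `Oc1nc2nonc2nc1Nc1ccc(C(F)(F)F)c(F)c1` has not been measured. It differs from compound 3 by fluoro in place of hydrogen on an aromatic carbon. This is the same kind of change as that from compound 1 to compound 2, though not the same: in compound 2 the fluoro sits ortho to a large group and meta to a butyl group, whereas in compound 4 it sits ortho to a trifluoromethyl group and meta to a large group. Because the first such step gave a 1.9-fold lower number from compound 1 to compound 2 (0.28 log units; within the scatter), compound 4 is expected to show a step of about a 1.9-fold lower number from compound 3 to compound 4 (0.28 log units; within the scatter) in this assay. Compound 4 is thus estimated at 5500 nM, most likely between 2500 nM and 12000 nM.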

Compound 4, half-maximal effective concentration: 11600 nM
For compound 4 the middle estimate is 2.1-fold (0.32 log units) below the measured one; the measured number falls inside the stated range.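

In this assay, the same fluoro change on the core of compound 3 brought a 1.1-fold higher number from compound 3 to compound 4 (0.05 log units; within the scatter). Set beside the earlier step, this gives no sign that the change behaves differently on the two cores: the same change on two cores in this assay, a 1.9-fold lower number (0.28 log units; within the scatter) from compound 1 to compound 2 and a 1.1-fold higher number (0.05 log units; within the scatter) from compound 3 to compound 4, 2.1-fold (0.33 log units) apart, within the scatter of two such steps. Each step and the gap between them lie within the usual scatter, so the data show no measurable effect of the fluoro on either core, but they do not prove that the step is identical on both, and two pairs alone cannot establish a rule for the series.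

The compounds shown leave open whether a step beyond the scatter would appear with a different group in place of the fluoro, such as a chlorine, a methoxy group, an amine or a carboxylic acid. They also leave open how a longer chain than butyl, with or without the fluoro, would read in this assay.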